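The compounds below may be only part of what the source reports. "The series", "measured", "known", "first", "only" and "open" are said of these compounds alone.

Measured compounds:
- compound 1, `C=CCCSC[C@H](NC(=O)c1cc(OC)c(OC)c(OC)c1)C(=O)OC`: 27300 nM
- compound 2, `C#CCSC[C@H](NC(=O)c1cc(OC)c(OC)c(OC)c1)C(=O)OC`: 53200 nM

Both numbers come from an assay on RAW264.7 cells for antagonist activity at Toll-like receptor 2 (Mus musculus), read by Griess assay, with a stated time of 24 h; on this read-out lower numbers stand for stronger inhibition and higher numbers for weaker inhibition. Compound 2 is set apart from compound 1 only by a 1.9-fold higher number from compound 1 to compound 2 (0.29 log units; within the scatter), and as that step is within the scatter, the two compounds cannot be told apart on these numbers; compound 2 simply holds the upper of the two values.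

Compound 3, `COC(=O)[C@H](CSCc1ccccc1)NC(=O)c1cc(OC)c(OC)c(OC)c1`, has not yet been measured. It differs from compound 2 in one place: phenyl in place of ethynyl on a saturated chain carbon bound to a sulfur. Among the measured compounds shown here, the only step measured so far, a 1.9-fold higher number from compound 1 to compound 2 (0.29 log units; within the scatter), touches the same saturated chain carbon bound to a sulfur, but it exchanged allyl for ethynyl and stayed within the scatter; no measured pair exchanges a small chain group for a ring, so nothing in the data fixes a direction for the entry of phenyl.

Compound 3 is therefore expected to come out near compound 2, with a 1.5-fold lower number from compound 2 to compound 3 (0.18 log units; within the scatter) counted as the likely size of the move. Compound 3 is estimated at 35000 nM in this assay, with a range from 10000 nM to 120000 nM.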

Compound 3, half-maximal inhibitory concentration: 32700 nM
Beside the measured number, compound 3's estimate is 1.1-fold (0.03 log units) above it, and the stated range covers the measured number.
By their numbers in this assay, from the lowest: compounds 1, 3 and 2 (each within the scatter of the next).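

In this assay the exchange of ethynyl for phenyl on the saturated chain carbon bound to a sulfur gives a 1.6-fold lower number from compound 2 to compound 3 (0.21 log units; within the scatter) and the exchange of allyl for phenyl gives a 1.2-fold higher number from compound 1 to compound 3 (0.08 log units; within the scatter) so neither step involving the ring leaves the scatter. The position therefore carries a six-membered aromatic ring of carbon only, with 6 heavy atoms where ethynyl has 2, and the result still cannot be told apart from those of the two open-chain groups, something the earlier step between allyl and ethynyl alone could not show. No measurement is at hand that would account for this result.

Going by these compounds, all three groups at this position consist of carbon only, with no hydrogen-bond donors or acceptors and no net charge, so it remains open whether an amine, a carboxylic acid or a longer chain there would produce a step beyond the scatter. On these data alone, it is equally open whether any change outside this position would do so, since the rest of the molecule is the same in compound 1, compound 2 and compound 3.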